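The source may hold more compounds than are shown below. What is called first, only, known or untested is meant among the compounds shown, and "the series" means these compounds.

Measured compounds:
compound 1 `CC(C)CN1C(=O)c2ccccc2[C@H](C(=O)Nc2ccc(F)c(C#N)c2)[C@H]1c1ccoc1` — 15000 nM
compound 2 `CC(C)CN1C(=O)c2ccccc2[C@H](C(=O)Nc2ccc(F)c(C#N)c2)[C@H]1c1cncc(C#N)c1` — 60000 nM

In a physicochemical assay for solubility, in phosphate buffer, with a stated time of 18 h, at pH 7 (a higher number here means a more soluble compound, a lower number a less soluble compound), compound 2 stands highest of the two numbers; its nearest neighbour is compound 1, and the step of a 4.0-fold higher number from compound 1 to compound 2 (0.60 log units; beyond the scatter) is described as modest and beyond the scatter. Compound 3 `CC(C)CN1C(=O)c2ccccc2[C@H](C(=O)Nc2ccc(F)c(C#N)c2)[C@H]1c1cnsc1` has not yet been measured in this assay. It differs from compound 2 in one place: 1,2-thiazol-4-yl in place of 5-cyanopyridin-3-yl on a saturated ring carbon. Among the compounds with values here, only the step from compound 1 to compound 2 bears on this change, since it alters the same saturated ring carbon, and its size was a 4.0-fold higher number from compound 1 to compound 2 (0.60 log units; beyond the scatter). The group entering compound 3 is neither the furan-3-yl of compound 1 nor the 5-cyanopyridin-3-yl of compound 2, so a step back toward the number of compound 1 is expected but with little confidence in its size. For compound 3 the estimate in this assay is 30000 nM, within 10000 nM to 90000 nM, which means an expected step of a 2.0-fold lower number from compound 2 to compound 3 (0.30 log units; within the scatter).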

Compound 3, solubility: 20000 nM
Beside the measured number, compound 3's estimate is 1.5-fold (0.18 log units) above it; measured number inside the range.
By their numbers in this assay, from the lowest: compounds 1 and 3 (each within the scatter of the next); then compound 2.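

In this assay, a third group on the saturated ring carbon shows that the higher number of compound 2 does not carry over to 1,2-thiazol-4-yl: the change gives a 3.0-fold lower number from compound 2 to compound 3 (0.48 log units; beyond the scatter). Set against furan-3-yl, the same group gives a 1.3-fold higher number from compound 1 to compound 3 (0.12 log units; within the scatter), so these two five-membered aromatic rings cannot be told apart in this measurement, and compound 2 alone stands apart from them. No measurement here accounts for either step.

From the compounds shown here alone, the 5-cyanopyridin-3-yl of compound 2 brings a six-membered aromatic ring and a nitrile together, so it remains open which of the two goes with its higher number; a plain pyridin-3-yl would separate them. Going by these compounds, how an amine or a carboxylic acid on this same carbon would read also remains open.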